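The source may hold more compounds than are shown below. What is called first, only, known or untested is meant among the compounds shown, and "the series" means these compounds.

Measured in a functional assay on CWR22R cells (Homo sapiens) for antiproliferative activity, read by propidium iodide staining, with a stated time of 96 h; on this read-out higher numbers stand for weaker inhibition and lower numbers for stronger inhibition:

Compound 1 `CC(O)(CSc1cccc(S(F)(F)(F)(F)F)c1)C(=O)Nc1ccc(S(F)(F)(F)(F)F)cc1`: 17700 nM
Compound 2 `CC(O)(CSc1cccc(C(F)(F)F)c1)C(=O)Nc1ccc(S(F)(F)(F)(F)F)cc1`: 23400 nM

For the measured compounds named here, compound 2, at 23400 nM, cannot be told apart from compound 1, the only other measured compound. The two numbers lie within the scatter of repeated measurements. The next compound, compound 3 `CC(O)(CSc1cccc(OC(F)(F)F)c1)C(=O)Nc1ccc(S(F)(F)(F)(F)F)cc1`, keeps everything in compound 2 except one group. It has trifluoromethoxy in place of trifluoromethyl on an aromatic carbon, meta to a large group (trifluoromethoxy in place of trifluoromethyl on an aromatic carbon).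

Going by the values given here, the one measured exchange on this aromatic carbon is a 1.3-fold higher number from compound 1 to compound 2 (0.12 log units; within the scatter), and it stays within the scatter. On that evidence, no step beyond the scatter is expected in this assay, and no direction can be favoured. A single step is thin ground, and trifluoromethoxy has not yet been measured on this core, so the range is kept wide.

An estimated 1.2-fold lower number from compound 2 to compound 3 (0.07 log units; within the scatter) is expected, which would stay within the scatter. For compound 3 the expected value is 20000 nM, with an estimated range from 9000 nM to 40000 nM.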

Compound 3, half-maximal inhibitory concentration: 14000 nM
Beside the measured number, compound 3's estimate is 1.4-fold (0.15 log units) above it, and the stated range covers the measured number.
By their numbers in this assay, from the lowest: compounds 3, 1 and 2 (each within the scatter of the next).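

In this assay, putting trifluoromethoxy on this aromatic carbon in place of trifluoromethyl gives a 1.7-fold lower number from compound 2 to compound 3 (0.22 log units; within the scatter), and putting it in place of the group of 5 fluorine atoms and 1 sulfur atom gives a 1.3-fold lower number from compound 1 to compound 3 (0.10 log units; within the scatter). For the compounds shown here, all three groups seen on this carbon now read alike, so a third exchange has joined the first in staying within the scatter, and the added oxygen, with its hydrogen-bond acceptor, brings no step that can be read in this cell assay. Nothing measured here speaks to why these three groups give such similar numbers.

All three groups carry fluorine, so the compounds shown leave open whether an amine, a carboxylic acid or a longer carbon chain on this aromatic carbon would move the number beyond the scatter. The rest of the shared core stays the same in compound 1, compound 2 and compound 3, so these results also say nothing about how a change elsewhere in the molecule would read.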